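This account rests on a few compounds, and the source may have more. Where it says the series, first, only, none or still open, it means among the compounds named here.

Three compounds of the series have been run in an ADME assay on microsomes from liver (Mus musculus) for metabolic stability, read by LC-MS, using NADPH, with a stated time of 60 min, tested at 1 uM, in the presence of a further agent that is not named here; on this read-out higher numbers stand for fast clearance and lower numbers for slow clearance. Compound 1 `Clc1ccc2nc(-c3ccccn3)c(Nc3ccc4c(c3)OCCO4)n2c1` returns only a limit of the assay, > 1000 uL/min, and no number. Compound 2 `Cc1ccn2c(Nc3ccccn3)c(-c3ccccn3)nc2c1` gives 130 uL/min, the lower of the two numbers in hand. Compound 3 `COc1ccc2nc(-c3ccccn3)c(Nc3ccc(F)cc3)n2c1` gives 923 uL/min, a gap beyond the scatter; compounds 2 and 3 differ in more than one place, so the gap is read only as what the two values show and not as a single step.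

Compound 4 `Cc1ccn2c(Nc3ccc(F)cc3)c(-c3ccccn3)nc2c1` has not yet been measured in this assay. Against compound 2 it carries 4-fluorophenyl in place of pyridin-2-yl on a nitrogen on an aromatic ring. Among the measured compounds shown here, no measured pair isolates this change on the shared core of compound 2. For the measured compounds named here, the aryl group that enters is the one carried by compound 3, which gives 923 uL/min in this assay, so a rise in clearance, beyond the scatter, is expected a 3.1-fold higher number from compound 2 to compound 4 (0.49 log units; beyond the scatter). Compound 4 is estimated at 400 uL/min, with a range from 150 uL/min to 1000 uL/min, pending the measurement.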

Compound 4, intrinsic clearance in a liver preparation (reported as CLH), per the amount of preparation that the assay uses: 354 uL/min
Estimate against measurement, compound 4: 1.1-fold (0.05 log units) above; measured number inside the range.
By their numbers in this assay, from the lowest: compound 2; then compound 4; then compound 3. At a limit, above all of these: compound 1.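

Exchanging pyridin-2-yl for 4-fluorophenyl on a nitrogen on an aromatic ring, with the rest of the core of compound 2 unchanged, gives a 2.7-fold higher number from compound 2 to compound 4 (0.44 log units; beyond the scatter) in this assay. Among the compounds shown here, this group alone therefore moves clearance beyond the scatter, a reading that the earlier compounds could not give, as no two of them differed in only one place. The data at hand give no measured property that accounts for this step.

As far as these compounds go, whether the same exchange gives a step of similar size on the core of compound 3 or compound 1 remains open. Also open, from the compounds shown here alone, is where an unsubstituted phenyl group or a cyclohexyl group on this nitrogen would fall relative to compound 2 and compound 4 in this assay.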